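This account rests on a few compounds, and the source may have more. Where it says the series, first, only, none or still open, it means among the compounds named here.

Of the compounds shown here, two have so far been measured in a functional assay for antagonist activity at transient receptor potential cation channel subfamily V member 1 (Homo sapiens), read by FLIPR and calcium flux; on this read-out lower numbers stand for stronger inhibition and higher numbers for weaker inhibition. Compound 1 `O=C1COc2ccc(NC(=O)C3CCN(c4cccc(Br)c4)CC3)cc2N1` gives 330 nM, the lowest of the two numbers. Compound 2 `CC(=O)N1CCc2ccc(NC(=O)C3CCN(c4cccc(C(F)(F)F)c4)CC3)cc21` differs from compound 1 both in its core and in the aryl group on the ring amine; in this assay compound 2 gives 800 nM, a higher number whose gap from compound 1 lies beyond the usual scatter. Because the two differ in more than one place, nothing can be pinned on either change alone.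

Compound 3 `O=C1COc2ccc(NC(=O)C3CCN(c4ccccc4C(F)(F)F)CC3)cc2N1` has not yet been measured. It keeps the core of compound 1 and alters only the aryl group: 2-(trifluoromethyl)phenyl in place of 3-bromophenyl on an amine nitrogen in a ring. Among the compounds with values here, no measured pair shows this exact exchange, so the expectation rests on compound 1 alone. The step from compound 1 to compound 3 is expected to be modest, a 1.7-fold higher number from compound 1 to compound 3 (0.22 log units; within the scatter), perhaps toward weaker inhibition. Compound 3 is estimated at 550 nM, within a range of 150 nM to 2500 nM.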

Compound 3, half-maximal inhibitory concentration: 380 nM
Compound 3: middle estimate off by 1.4-fold (0.16 log units), on the high side, and the stated range covers the measured number.
By their numbers in this assay, from the lowest: compounds 1 and 3 (each within the scatter of the next); then compound 2.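

With the core of compound 1 held constant, the aryl group on the ring amine can now be read on its own: in this assay the exchange gives a 1.2-fold higher number from compound 1 to compound 3 (0.06 log units; within the scatter). The two groups therefore cannot be told apart in this assay, even though 2-(trifluoromethyl)phenyl has 10 heavy atoms against 7 for 3-bromophenyl and carries fluorine instead of bromine. Nothing measured here offers an explanation for this close match.

This single exchange leaves open whether 2-(trifluoromethyl)phenyl and 3-bromophenyl would also read alike on the core of compound 2. It also leaves open how this position would respond to a different kind of group on the amine nitrogen, such as a pyridine ring, a carboxylic acid or a simple alkyl chain.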